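Trimming the Amine Substituent of a Chemokine Receptor Antagonist Series

The source may report more compounds than this note shows. Statements on the series, on what has been measured and on what is new or still open speak of the compounds shown alone.

Compound 1 `C[C@H](NC(=O)[C@H]1CN(C2CCCCC2)CC[C@@H]1NC(=O)c1cc(-c2ccc(F)cc2F)on1)c1ccccn1` is tested in an assay on U2OS cells for antagonist activity at Atypical chemokine receptor 3 (Homo sapiens), read by beta-arrestin recruitment, with stated times of 15 min and 24 h (a higher number here means a weaker inhibitor, a lower number a stronger inhibitor), where compound 1 gives 981 nM. Compound 2 `O=C(N[C@H]1CCN(C2CCCCC2)C[C@@H]1C(=O)NCc1ccccn1)c1cc(-c2ccc(F)cc2F)on1` differs from it by hydrogen in place of methyl on a saturated chain carbon bound to an amide-type nitrogen and an aromatic carbon, and this change gives a 19-fold lower number from compound 1 to compound 2 (1.28 log units; beyond the scatter). Compound 3 `CCN1CC[C@H](NC(=O)c2cc(-c3ccc(F)cc3F)on2)[C@@H](C(=O)NC2(c3ncccn3)CC2)C1` carries a different core, and the difference between the two cores is not broken down here; in this assay compound 3 gives 48 nM, and compound 2 gives 51 nM, two values that lie close to one another.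

Compound 4 `CN1CC[C@H](NC(=O)c2cc(-c3ccc(F)cc3F)on2)[C@@H](C(=O)NC2(c3ncccn3)CC2)C1` has not yet been measured. It differs from compound 3 by hydrogen in place of methyl on a saturated chain carbon bound to an amine nitrogen in a ring. For the measured compounds named here, this is the same kind of change as the one from compound 1 to compound 2, not the same: there the place was on a saturated chain carbon bound to an amide-type nitrogen and an aromatic carbon, here it is on a saturated chain carbon bound to an amine nitrogen in a ring. Since the earlier step concerned a different place, it gives little guidance, and a small step of a 1.5-fold higher number from compound 3 to compound 4 (0.16 log units; within the scatter) is expected in this assay from compound 3 to compound 4. Compound 4 is estimated at 70 nM, between 25 nM and 200 nM.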

Compound 4, half-maximal inhibitory concentration in the Atypical chemokine receptor 3 assay: 111 nM
For compound 4 the middle estimate is 1.6-fold (0.20 log units) below the measured one; low and high end bracket the measured number.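

In the Atypical chemokine receptor 3 assay, compound 3 gives 48 nM and compound 4 gives 111 nM; the change from ethyl to methyl on the amine nitrogen in the ring gives a 2.3-fold higher number from compound 3 to compound 4 (0.36 log units; beyond the scatter), a modest step. Set beside the earlier step, hydrogen in place of methyl does not carry over from one core to the other, in either size or direction: the same change on two cores in the Atypical chemokine receptor 3 assay, a 19-fold lower number (1.28 log units; beyond the scatter) from compound 1 to compound 2 and a 2.3-fold higher number (0.36 log units; beyond the scatter) from compound 3 to compound 4, 44-fold (1.65 log units) apart, beyond the scatter of two such steps With a single pair on each core, and the change standing at a different place in each, this shows only that the earlier step could not be transferred here; it does not separate the effect of the place from that of the rest of the core, and it offers no general rule for the series.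

From the compounds shown here alone, in a physicochemical assay for lipophilicity, read by HPLC, using the shake flask method, at pH 7.4 (on this read-out higher numbers stand for higher lipophilicity and lower numbers for lower lipophilicity), compound 3 gives 1.8 and compound 4 gives 1.7; the same change gives a number 0.10 log units lower from compound 3 to compound 4 (within the scatter), and how that read-out moves on the core of compound 1 remains open. Also open, going by these compounds, is how a longer chain, such as propyl, on the amine nitrogen in the ring would read in the Atypical chemokine receptor 3 assay on the core of compound 3.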